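The source may report more compounds than this note shows. Statements on the series, on what has been measured and on what is new or still open speak of the compounds shown alone.

Measured compounds in an assay on CHO cells for displacement of a labelled ligand from prostaglandin E2 receptor EP3 subtype (Homo sapiens), read by radioligand binding; a higher number here means a weaker inhibitor, a lower number a stronger inhibitor:

- compound 1, `CC(C)C(c1ccc(-c2ccc3cccc(F)c3c2)[nH]c1=O)N1CCCCS1(=O)=O`, gives 14 nM
- compound 2, `CC(C)C(Nc1nnc[nH]1)c1ccc(-c2ccc3cccc(F)c3c2)[nH]c1=O`, gives 22 nM
- compound 3, `CC(C)C(c1cnc(N)s1)c1ccc(-c2ccc3cccc(F)c3c2)[nH]c1=O`, gives 16 nM

Compound 3 holds the second highest of the three numbers, yet all three sit within the scatter of one another: a 1.1-fold higher number from compound 1 to compound 3 (0.06 log units; within the scatter), a 1.4-fold lower number from compound 2 to compound 3 (0.14 log units; within the scatter), and likewise a 1.6-fold higher number from compound 1 to compound 2 (0.20 log units; within the scatter). Every exchange of the group on the saturated chain carbon bound to an aromatic carbon and a saturated chain carbon has so far left this assay essentially unmoved.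

Compound 4, `CC(C)NC(=O)CC(c1ccc(-c2ccc3cccc(F)c3c2)[nH]c1=O)C(C)C`, carries the change ((isopropylcarbamoyl)methyl in place of 2-amino-1,3-thiazol-5-yl on a saturated chain carbon bound to an aromatic carbon and a saturated chain carbon). For the measured compounds named here, no measured step exchanges a ring for an open chain at this place, so the three steps above bear on it only indirectly. They suggest a small step with no clear direction beyond the scatter. Compound 4 is expected to show a step of a 1.6-fold higher number from compound 3 to compound 4 (0.19 log units; within the scatter). Compound 4 is therefore expected to give 25 nM, within a range from 8 nM to 80 nM.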

Compound 4, inhibition constant: 5.8 nM
Compound 4: middle estimate off by 4.3-fold (0.63 log units), on the high side, outside the stated range (below it).
By their numbers in this assay, from the lowest: compound 4; then compounds 1, 3 and 2 (each within the scatter of the next).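

In this assay, the position on a saturated chain carbon bound to an aromatic carbon and a saturated chain carbon does respond to the group it carries. (Isopropylcarbamoyl)methyl gives a 2.8-fold lower number from compound 3 to compound 4 (0.44 log units; beyond the scatter), a 3.8-fold lower number from compound 2 to compound 4 (0.58 log units; beyond the scatter) and a 2.4-fold lower number from compound 1 to compound 4 (0.38 log units; beyond the scatter). For the compounds shown here, these are the first steps at this place beyond the scatter, modest in size, and they come with an open chain in place of a ring-bearing group.

On these data alone, it stays open whether the carbamoyl part or the open chain alone carries the step; a carboxylic acid or a longer alkyl chain at this place would separate the two. The data shown offer no explanation for these steps.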